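Replacing the acetyl of compound 2

This account rests on a few compounds, and the source may have more. Where it says the series, first, only, none or still open, it means among the compounds named here.

Measured so far in a functional assay on HepG2 cells (Homo sapiens) for inhibition, read by MTT assay, with a stated time of 48 h; a higher number here means a weaker inhibitor, a lower number a stronger inhibitor:
Compound 1 `CC(=O)O[C@@H]1C[C@@H](OC(=O)c2ccccc2)/C(C)=C/[C@H]2[C@@H](OC(=O)c3ccccc3)[C@@H](C)[C@H](O)[C@]2(OC(C)=O)[C@H](O)[C@](C)(O)/C=C/C1(C)C`: > 150000 nM (a limit of the assay, not a number)
Compound 2 `CC(=O)O[C@@H]1C[C@@H](OC(=O)c2ccccc2)/C(C)=C/[C@H]2[C@@H](OC(=O)c3ccccc3)[C@@H](C)[C@H](OC(C)=O)[C@]2(OC(C)=O)[C@H](O)[C@](C)(O)/C=C/C1(C)C`: 93300 nM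

In this assay, for the measured compounds named here, compound 2 gives 93300 nM, the only true number so far. Compound 3 `CC(=O)O[C@@H]1C[C@@H](OC(=O)c2ccccc2)/C(C)=C/[C@H]2[C@@H](OC(=O)c3ccccc3)[C@@H](C)[C@H](OS(=O)(=O)c3ccc(C)cc3)[C@]2(OC(C)=O)[C@H](O)[C@](C)(O)/C=C/C1(C)C` carries (4-methylphenyl)sulfonyl in place of acetyl on an oxygen on a saturated carbon. Going by the values given here, only one measured step concerns such an oxygen: an at least 1.6-fold lower number from compound 1 to compound 2 (0.20 log units; that floor lies within the scatter), and it stays within the scatter. That single step gives no ground for expecting a change beyond the scatter, so the expected step is a 1.2-fold lower number from compound 2 to compound 3 (0.09 log units; within the scatter). For compound 3 the estimated value is 75000 nM, with an expected range from 30000 nM to 150000 nM.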

Compound 3, half-maximal inhibitory concentration: > 150000 nM
Compound 3 was reported as a limit; the forecaster's own chance of this, stated with the estimate: 20%; middle value at least 2.0-fold (0.30 log units) away from the limit.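

In this assay compound 3 stands as a limit, not a number: > 150000 nM. The exchange gives an at least 1.6-fold higher number from compound 2 to compound 3 (0.20 log units; that floor lies within the scatter), so (4-methylphenyl)sulfonyl on this oxygen brings no visible gain over acetyl. Of the three groups shown here, only the acetyl of compound 2 yields a true number, while hydrogen and (4-methylphenyl)sulfonyl end at the same limit: the limit of > 150000 nM in this assay, at which 2 of the 3 values shown sit.

The step from compound 1 to compound 3 joins two limits and cannot be read. From the compounds shown here alone, whether an amine, a carboxylic acid or a longer acyl chain on this oxygen would give a true number stays open.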